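From 2-Hydroxyphenyl to 3-Hydroxyphenyl in Compound 3

A few compounds are considered here, and "the series" means these few. Any claim that something is new, unique, unknown or untested is made for them only; others in the source may bear on it.

- Compound 1 `Cc1cc(C)cc(S(=O)(=O)c2c(C(=O)Nc3cccc(O)c3)[nH]c3ccc(Cl)cc23)c1`: 24600 nM
- Compound 2 `Cc1cc(C)cc(S(=O)(=O)c2c(C(=O)NCc3ccccc3O)[nH]c3ccc(Cl)cc23)c1`: 23800 nM
- Compound 3 `Cc1cc(C)cc(S(=O)(=O)c2c(C(=O)NC(C)c3ccccc3O)[nH]c3ccc(Cl)cc23)c1`: 21800 nM

In an ADME assay on MT4 cells (Homo sapiens) for cytotoxicity, read by MTT assay (a higher number here means that more compound is tolerated, a lower number that less compound is tolerated), compound 3 gives 21800 nM, a value within the scatter of those of the other two measured compounds. Compound 4 `Cc1cc(C)cc(S(=O)(=O)c2c(C(=O)NC(C)c3cccc(O)c3)[nH]c3ccc(Cl)cc23)c1` has not yet been measured. It carries 3-hydroxyphenyl in place of 2-hydroxyphenyl on a saturated chain carbon bound to an amide-type nitrogen and a saturated chain carbon.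

For the measured compounds named here, no measured step makes exactly this swap. The closest is a 1.0-fold lower number from compound 1 to compound 2 (0.01 log units; within the scatter), which also replaces 3-hydroxyphenyl with a 2-hydroxy group but changes the link to the amide-type nitrogen as well. Adding the methyl gave a 1.1-fold lower number from compound 2 to compound 3 (0.04 log units; within the scatter), and the combined change gave a 1.1-fold lower number from compound 1 to compound 3 (0.05 log units; within the scatter). All three steps are small, so no shift beyond the scatter is expected in this assay. The estimated change is a 1.1-fold higher number from compound 3 to compound 4 (0.02 log units; within the scatter), with no firm direction expected. For compound 4 the expected value is 23000 nM, with an estimated range of 13000 nM to 40000 nM.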

Compound 4, half-maximal cytotoxic concentration: 16000 nM
For compound 4 the middle estimate is 1.4-fold (0.16 log units) above the measured one; measured number inside the range.
By their numbers in this assay, from the lowest: compounds 4, 3, 2 and 1 (each within the scatter of the next).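

For the compounds shown here, the first direct reading of 3-hydroxyphenyl in place of 2-hydroxyphenyl on a saturated chain carbon bound to an amide-type nitrogen and a saturated chain carbon is a 1.4-fold lower number from compound 3 to compound 4 (0.13 log units; within the scatter) in this assay and this swap therefore does not move the number beyond the scatter. The two wider changes on the amide-type nitrogen, a 1.5-fold lower number from compound 2 to compound 4 (0.17 log units; within the scatter) and a 1.5-fold lower number from compound 1 to compound 4 (0.19 log units; within the scatter) also stay within the scatter, so all four compounds remain indistinguishable in this measurement. No measurement shown offers an explanation for the small differences that remain.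

The compounds shown leave open whether 4-hydroxyphenyl at this same place would also stay within the scatter. They also leave open what an aminophenyl or a carboxylic acid in place of the hydroxyphenyl would give in this assay and whether any such group would shift the number beyond the scatter.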